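Shortening the Amide Side Chain: Compound 4 in Cytotoxicity

The source may hold more compounds than are shown below. What is called first, only, known or untested is meant among the compounds shown, and "the series" means these compounds.

Compound 1, `CCCC(=O)OCSc1ccc(OC(F)(F)F)cc1C(=O)NC(C)(C)C(N)=O`: < 56.1 uM
Compound 2, `CCCC(=O)OCSc1ccc(OC)cc1C(=O)NCCC(N)=O`: > 100 uM
Compound 3, `CCCC(=O)OCSc1ccccc1C(=O)NCCCCC(N)=O`: 51.7 uM

All three were tested in an ADME assay on CEM-SS cells (Homo sapiens) for cytotoxicity, read by XTT assay, with a stated time of 6 days; on this read-out higher numbers stand for lower toxicity in this test and lower numbers for higher toxicity in this test. For compound 1 the value is a limit of the test, (the limit of < 56.1 uM in this assay, at which 1 of the 3 values shown sits). For compound 2 the value is also a limit, (the limit of > 100 uM in this assay, at which 1 of the 3 values shown sits). Among the compounds with values here, compound 3 therefore stands as the only plain number among the three. Compound 4, `CCCC(=O)OCSc1ccccc1C(=O)NCC(=O)NC`, keeps the core of compound 3 but carries methylcarbamoyl in place of 3-carbamoylpropyl on a saturated chain carbon bound to an amide-type nitrogen. Within the data shown here, no measured pair of compounds here differs by a single change, so the effect of this alteration cannot be read from the data. I expect a step of a 1.3-fold higher number from compound 3 to compound 4 (0.10 log units; within the scatter) from compound 3 to compound 4, not clearly beyond the usual scatter. For compound 4 the estimated value is 65 uM, with a range from 25 uM to 120 uM.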

Compound 4, half-maximal toxic concentration: > 100 uM
Compound 4: no number, only a limit (the forecaster's own chance of this, stated with the estimate: 35%); middle value at least 1.5-fold (0.18 log units) from the limit.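

Methylcarbamoyl in place of 3-carbamoylpropyl, on a saturated chain carbon bound to an amide-type nitrogen, gives an at least 1.9-fold higher number from compound 3 to compound 4 (0.28 log units; that floor lies within the scatter) in this assay. Within the data shown here, this is the first step that can be read at this position, and it shows that the shorter group does not bring the number down. Compound 4 gives a limit of the test, not a plain number: the limit of > 100 uM in this assay, at which 2 of the 4 values shown sit.

Going by these compounds, the true size of the step therefore stays open. So does the outcome with an amine or a carboxylic acid at this place.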